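The source may report more compounds than this note shows. Statements on the series, on what has been measured and on what is new or still open speak of the compounds shown alone.

Of the compounds shown here, three built on the same core have been tested in a functional assay on the whole organism for inhibition, with Rattus norvegicus as the target (on this read-out lower numbers stand for an effect already at smaller amounts and higher numbers for an effect only at larger amounts of compound), and none of them gave a number. Compound 1, with the structure `CC1CC/C(=N\Nc2ccccc2I)c2ncc(C(=O)O)c(=O)n21`, reached only a limit of the assay, > 1000 umol/kg. Compound 2, with the structure `CC1CC/C(=N\Nc2ccc(I)cc2)c2ncc(C(=O)O)c(=O)n21`, likewise reached only a limit, > 1000 umol/kg. Compound 3, with the structure `CC1CC/C(=N\Nc2ccccc2O)c2ncc(C(=O)O)c(=O)n21`, stopped at a different limit, > 100 umol/kg. Compound 2 therefore stands at the limit of > 1000 umol/kg in this assay, at which 2 of the 3 values shown sit, together with compound 1, while compound 3 stands at the limit of > 100 umol/kg in this assay, at which 1 of the 3 values shown sits. Because all three values are limits, the steps between them cannot be read: a step that the two limits leave unreadable from compound 1 to compound 2, a step that the two limits leave unreadable from compound 1 to compound 3 and a step that the two limits leave unreadable from compound 2 to compound 3.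

Compound 4, with the structure `CNC(=O)c1ccc(N/N=C2\CCC(C)n3c2ncc(C(=O)O)c3=O)cc1`, has not yet been measured in this assay. It differs from compound 2 in one place: methylcarbamoyl in place of iodo on an aromatic carbon. Going by the values given here, no measured step shows what this exchange does, since the only changes seen so far, a move of the iodo group and its replacement by hydroxy, were all hidden by limits. Among the compounds with values here, nothing among the measured compounds points to a strong effect in either direction. The expectation for compound 4 is therefore a value near the limit of compound 2, with the step that the limit leaves unreadable from compound 2 to compound 4 expected to stay within the scatter. Compound 4 is estimated at 1500 umol/kg, in the range 300 umol/kg to 10000 umol/kg.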

Compound 4, dose for 50% inhibition: > 100 umol/kg
Compound 4 gave a limit, no number; the forecaster's own chance of this, stated with the estimate: 70%; the middle value is on the limit's open side.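

Compound 2 and compound 4 each ended at a limit of the assay, not at a number, so the step between them cannot be read. The compounds shown leave open whether methylcarbamoyl in place of iodo on an aromatic carbon changes the result in this assay at all, and if it does, in which direction and by how much.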